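Propargyl Thioether Carried onto the Propyl Triazole

The source may hold more compounds than are shown below. What is called first, only, known or untested is meant among the compounds shown, and "the series" means these compounds.

compound 1 `C#CCSc1nnc(C)n1N1C(=O)c2ccccc2C1=O` — > 200000 nM
compound 2 `CCCc1nnc(SCc2ccccc2)n1N1C(=O)c2ccccc2C1=O` — > 200000 nM

In a functional assay on HepG2 cells (Homo sapiens) for cytotoxicity, read by MTT assay, with a stated time of 48 h (a higher number here means a weaker inhibitor, a lower number a stronger inhibitor), compound 1 gives only an assay limit, > 200000 nM. Compound 2 also stops at a limit, > 200000 nM. Compound 2 therefore stands at the limit of > 200000 nM in this assay, at which 2 of the 2 values shown sit, with no number that would rank it. Compound 3 `C#CCSc1nnc(CCC)n1N1C(=O)c2ccccc2C1=O` differs from compound 2 by ethynyl in place of phenyl on a saturated chain carbon bound to a sulfur. Among the measured compounds shown here, no measured step covers this change, and the step that the limit leaves unreadable from compound 2 to compound 3 is expected to be none beyond the scatter, since compound 1 already carries the propargylsulfanyl group and gives > 200000 nM. Compound 3 is thus expected to sit near 300000 nM, within 100000 nM to 1000000 nM, most likely again as a limit.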

Compound 3, half-maximal inhibitory concentration: > 200000 nM
Compound 3: a limit, no number; the forecaster's own chance of this, stated with the estimate: 85%; the middle value is on the limit's open side.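

Compound 1, compound 2 and compound 3 all stop at a limit in this assay, so no step among them can be read: the limit of > 200000 nM in this assay, at which 3 of the 3 values shown sit.

The compounds shown leave open how these three rank against one another, and whether any change to the shared core would give a number rather than a limit.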